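Swapping 4-chlorophenyl for thiophen-2-yl in compound 3

A few compounds are considered here, and "the series" means these few. Any claim that something is new, unique, unknown or untested is made for them only; others in the source may bear on it.

Compound 2 `COc1cc(OC)c2c(=O)c(OCCCCOc3ccccc3/C=C/C(=O)/C=C/c3ccc(Cl)cc3)c(-c3cc(OC)c(OC)c(OC)c3)oc2c1` was tested in a functional assay on U-87MG ATCC cells for antiproliferative activity against U-87 MG (Homo sapiens), read by MTT assay, with a stated time of 48 h (on this read-out lower numbers stand for stronger inhibition and higher numbers for weaker inhibition), where compound 2 gave 21100 nM. Among the measured compounds shown here, its only measured relative is compound 1 `COc1cc(OC)c2c(=O)c(OCCCCOc3ccccc3/C=C/C(=O)/C=C/c3ccco3)c(-c3cc(OC)c(OC)c(OC)c3)oc2c1`, which in this assay gave 10700 nM; the two numbers lie within the usual scatter of each other, so neither compound can be placed ahead of the other. For the measured compounds named here, the single measured step, a 2.0-fold higher number from compound 1 to compound 2 (0.29 log units; within the scatter), came from putting 4-chlorophenyl in place of furan-2-yl on a double-bonded chain carbon bound to a double-bonded chain carbon and did not move the number beyond the scatter. Compound 3 `COc1cc(OC)c2c(=O)c(OCCCCOc3ccccc3/C=C/C(=O)/C=C/c3cccs3)c(-c3cc(OC)c(OC)c(OC)c3)oc2c1` has not been measured; it differs from compound 2 by thiophen-2-yl in place of 4-chlorophenyl on a double-bonded chain carbon bound to a double-bonded chain carbon. This change is close to the reverse of the measured step, a five-membered heteroaryl again replacing the 4-chlorophenyl, so in this assay no move beyond the scatter is expected, at most a drift back toward the number of compound 1, a 1.5-fold lower number from compound 2 to compound 3 (0.18 log units; within the scatter). Compound 3 is therefore expected to give 14000 nM, with a range from 6000 nM to 30000 nM.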

Compound 3, half-maximal inhibitory concentration: 21100 nM
The estimate for compound 3 lay 1.5-fold (0.18 log units) below the measured number, and the stated range covers the measured number.
By their numbers in this assay, from the lowest: compounds 1, 2 and 3 (each within the scatter of the next).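

With thiophen-2-yl at this place, a third aromatic ring now stands on the double-bonded chain carbon, and in this assay the swap from 4-chlorophenyl gave (no change at the digits printed from compound 2 to compound 3 (within the scatter)). The swap from furan-2-yl gave (a 2.0-fold higher number from compound 1 to compound 3 (0.29 log units; within the scatter)), so neither the five-membered ring with sulfur nor the six-membered ring with chlorine separates from the furan-2-yl compound, and compounds 1, 2 and 3 cannot be ranked. The earlier pair covered only one exchange, whereas these three compounds show that all three exchanges among these rings stay within the scatter. No measurement is available that would explain this result.

As far as these compounds go, it remains open whether an amine or a carboxylic acid on the ring at this place would move the number beyond the scatter. The same question stands for a longer chain in place of the ring.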